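From tert-butyl carbonyl to hydroxy side chain: working notes

The source may hold more compounds than are shown below. What is called first, only, known or untested is meant among the compounds shown, and "the series" means these compounds.

Values measured so far in a functional assay on PC-3 cells (Homo sapiens), read by MTT assay, with a stated time of 48 h (on this read-out higher numbers stand for weaker inhibition and lower numbers for stronger inhibition), are these
- compound 1 `CCn1c(C(=O)NCCN)ccc1C(CC)(CC)c1ccc(OCC(O)C(C)(C)C)c(C)c1` at 940 nM measured
- compound 2 `CC[C@@H](C)[C@H](NC(=O)c1ccc(C(CC)(CC)c2ccc(OCC(=O)C(C)(C)C)c(C)c2)n1CC)C(=O)O` at 1600 nM measured

Compound 2 at 1600 nM sits within the scatter of compound 1 at 940 nM and the two numbers set no order between them. Compound 3 `CC[C@@H](C)[C@H](NC(=O)c1ccc(C(CC)(CC)c2ccc(OCC(O)C(C)(C)C)c(C)c2)n1CC)C(=O)O` has not been measured. It differs from compound 2 in one place, on a saturated chain carbon bound to an oxygen on an aromatic ring, with 1-hydroxy-2,2-dimethylpropyl in place of (tert-butyl)carbonyl (1-hydroxy-2,2-dimethylpropyl in place of (tert-butyl)carbonyl on a saturated chain carbon bound to an oxygen on an aromatic ring). Among the measured compounds shown here, no measured pair isolates this change. Compound 1 at 940 nM carries the same 2-hydroxy-3,3-dimethylbutoxy group as compound 3 but differs from it elsewhere, and its number offers no sign of a large move in either direction. In this assay no step beyond the scatter is expected. The estimated change is a 1.2-fold lower number from compound 2 to compound 3 (0.09 log units; within the scatter) and it is expected to stay within the scatter. For compound 3 the estimated value is 1300 nM with an expected range from 550 nM to 3000 nM for repeat measurements.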

Compound 3, half-maximal inhibitory concentration: 1900 nM
Estimate against measurement, compound 3: 1.5-fold (0.16 log units) below; the range from low to high includes it.
By their numbers in this assay, from the lowest: compounds 1, 2 and 3 (each within the scatter of the next, the first and the last beyond it).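

In this assay, among the compounds shown here, 1-hydroxy-2,2-dimethylpropyl in place of (tert-butyl)carbonyl on a saturated chain carbon bound to an oxygen on an aromatic ring gives a 1.2-fold higher number from compound 2 to compound 3 (0.07 log units; within the scatter); this is the first pair to isolate the change, and it shows that the gain of one hydrogen-bond donor at this place produces no step beyond the scatter. For the compounds shown here, with 1-hydroxy-2,2-dimethylpropyl held constant, 1-carboxy-2-methylbutyl in place of 2-aminoethyl on an amide-type nitrogen gives a 2.0-fold higher number from compound 1 to compound 3 (0.31 log units; beyond the scatter), so the only step beyond the scatter, a modest one, lies at the amide-type nitrogen and not at the position of the hydroxy and carbonyl groups. No measurement is available that accounts for either step.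

Going by these compounds, it remains open whether the exchange of (tert-butyl)carbonyl for 1-hydroxy-2,2-dimethylpropyl reads the same with 2-aminoethyl on the amide-type nitrogen. On these data alone, it is also open whether an amine or a methyl ether at the place of the hydroxy group, or a longer chain in place of the tert-butyl end, would move the number beyond the scatter.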